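The compounds below may be only part of what the source reports. "The series", "measured", "known", "first", "only" and "open" are said of these compounds alone.

Measured compounds in the series:

- compound 1, `COc1ccc(C2=C(c3cc(OC)c(OC)c(OC)c3)C(=O)C(O)C2)cc1`: < 1 ug/mL
- compound 2, `COc1ccc(OC)c(C2=C(c3cc(OC)c(OC)c(OC)c3)C(=O)CC2O[SiH2]C(C)(C)C)c1`: 6.5 ug/mL
- compound 3, `COc1ccc(C2=C(c3cc(OC)c(OC)c(OC)c3)C(=O)C(O[SiH2]C(C)(C)C)C2)cc1`: 16 ug/mL

The read-out throughout is an ADME assay on ECV-304 cells (Homo sapiens) for cytotoxicity, read by MTT assay, with a stated time of 72 h; on this read-out higher numbers stand for weaker inhibition and lower numbers for stronger inhibition. Compound 1 sits at the limit of this assay, < 1 ug/mL, so its number is a limit and not a measured value (the limit of < 1 ug/mL in this assay, at which 1 of the 3 values shown sits). Compound 3 gives 16 ug/mL and compound 2 gives 6.5 ug/mL; between these two measured numbers, compound 2 stands lower, beyond the scatter.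

For the measured compounds named here, the one step that can be counted is from compound 3 to compound 1: a hydrogen atom in place of a group of 5 heavy atoms (4 carbon, 1 silicon; no ring), on an oxygen on a saturated carbon. This step gives an at least 16-fold lower number from compound 3 to compound 1 (1.20 log units; beyond the scatter), a large move to a lower number that ends at the limit.

Compound 4, `COc1ccc(OC)c(C2=C(c3cc(OC)c(OC)c(OC)c3)C(=O)CC2O)c1`, is not yet measured in this assay. It stands to compound 2 as compound 1 stands to compound 3: a hydrogen atom in place of a group of 5 heavy atoms (4 carbon, 1 silicon; no ring), on an oxygen on a saturated carbon. The two place lines read the same, so this is the same change, made on a different core; the difference between the core of compound 2 and the core of compound 3 is not broken down here.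

Since compound 2 starts lower than compound 3 and the earlier change produced an at least 16-fold lower number from compound 3 to compound 1 (1.20 log units; beyond the scatter), a step of similar size is expected for compound 4, a 13-fold lower number from compound 2 to compound 4 (1.11 log units; beyond the scatter), which would carry it to or past the limit of this assay. Compound 4 is therefore estimated at 0.5 ug/mL, with a range of 0.15 ug/mL to 1.6 ug/mL, and a fair chance that this assay reports only a limit.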

Compound 4, half-maximal inhibitory concentration: > 100 ug/mL
Compound 4 gave a limit, no number; the forecaster's own chance of this, stated with the estimate: 55%; middle value at least 200-fold (2.30 log units) away from the limit.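

In this assay, putting a hydrogen atom in place of the group of 5 heavy atoms (4 carbon, 1 silicon) on an oxygen on a saturated carbon gives an at least 15-fold higher number from compound 2 to compound 4 (1.18 log units; beyond the scatter), so the same change runs in opposite directions on the two cores: the same change on two cores in this assay, an at least 16-fold lower number (1.20 log units; beyond the scatter) from compound 3 to compound 1 and an at least 15-fold higher number (1.18 log units; beyond the scatter) from compound 2 to compound 4, at least 240-fold (2.39 log units) apart, beyond the scatter of two such steps

From the compounds shown here alone, compound 4 gives > 100 ug/mL, which is a limit and not a number, so the true size of the step to compound 4 stays unknown.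

These two pairs show that the direction of this change does not carry from the core of compound 3 to the core of compound 2, but they do not show which difference between the two cores goes with the opposite outcome, or what the change would do on any further core.

Going by these compounds, with only hydrogen and this one silicon-bearing group on the oxygen, it remains open whether a methyl or an acetyl group there would follow the pair of compound 3 and compound 1 or the pair of compound 2 and compound 4. Also open, on these data alone, is how the two cores compare when they carry the same hydrogen, since compound 1 and compound 4 both stand at limits of this assay.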